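A few compounds are considered here, and "the series" means these few. Any claim that something is new, unique, unknown or untested is made for them only; others in the source may bear on it.

Measured so far:
compound 1 `CN(C)c1ccc(C(=O)Nc2cccc(NC(=O)COc3ccc4c(c3)OCCO4)c2)cc1` — > 10000 nM
compound 2 `Cc1ccc(C(=O)Nc2cccc(NC(=O)COc3ccc4c(=O)ccoc4c3)c2)cc1` — 183 nM

In an assay on isolated protein for inhibition of Rho-associated protein kinase 1 (Homo sapiens), read by scintillation counting, radiometric assay and 33P incorporation, with a stated time of 40 min, in the presence of a further agent that is not named here (on this read-out higher numbers stand for weaker inhibition and lower numbers for stronger inhibition), compound 1 reaches the limit > 10000 nM, which is a limit of the assay and not a number (the limit of > 10000 nM in this assay, at which 1 of the 2 values shown sits). Compound 2 gives 183 nM in this assay, the only number shown, and the one measured point of reference. Compound 3 `O=C(COc1ccc2c(=O)ccoc2c1)Nc1cccc(NC(=O)c2ccc(C(=O)O)cc2)c1` is not yet measured; it differs from compound 2 by carboxy in place of methyl on an aromatic carbon. No step between measured compounds is shown, so the expected step rests on the change alone: a modest loss in potency is expected, a 2.7-fold higher number from compound 2 to compound 3 (0.44 log units; beyond the scatter). Compound 3 is estimated at 500 nM, within a range from 120 nM to 2500 nM.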

Compound 3, half-maximal inhibitory concentration: 6890 nM
The estimate for compound 3 lay 14-fold (1.14 log units) below the measured number, outside the stated range (above it).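

In this assay, the aromatic carbon para to a large group proves sensitive to this change: carboxy in place of methyl gives a 38-fold higher number from compound 2 to compound 3 (1.58 log units; beyond the scatter) as a large loss from a single substitution. Compound 3 at 6890 nM still reads as a number, so inhibition is weakened but remains measurable. Nothing shown gives a reason for this loss. As far as these compounds go, whether an amine, a primary amide or a methyl ester at this carbon would keep the potency of compound 2 stays open. So does whether the loss would recur on another core.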